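Aryl exchange from compound 2 to compound 4

The compounds below may be only part of what the source reports. "The series", "measured", "known", "first", "only" and "open" are said of these compounds alone.

Measured in a physicochemical assay for solubility, in phosphate buffer, measured as kinetic solubility, at pH 7.4; a higher number here means a more soluble compound, a lower number a less soluble compound:
compound 1 `Cc1ccccc1-c1nc(CN2CCC(C(=O)NCCCN3CCCCC3)CC2)c(C)o1`: > 65 ug/mL (a limit)
compound 2 `Cc1oc(-c2c(F)cccc2F)nc1CN1CCC(C(=O)NCCCN2C[C@H](C)C[C@H](C)C2)CC1`: > 72 ug/mL (a limit)
compound 3 `Cc1ccccc1-c1nc(CN2CCC(C(=O)NCCN3C[C@H](C)C[C@H](C)C3)CC2)c(C)o1`: > 67 ug/mL (a limit)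

Compound 2 stands at > 72 ug/mL as a limit and not a number, and the two other values are limits too. Compound 4 `COc1cccc(Br)c1-c1nc(CN2CCC(C(=O)NCCCN3C[C@H](C)C[C@H](C)C3)CC2)c(C)o1` differs from compound 2 by 2-bromo-6-methoxyphenyl in place of 2,6-difluorophenyl on an aromatic carbon. Going by the values given here, the one measured step that the two limits leave unreadable from compound 1 to compound 3 sits elsewhere in the molecule and gives no size to carry over. Expected in this assay is no shift beyond the scatter, with a step that the limit leaves unreadable from compound 2 to compound 4 as the estimate for this change. That expectation rests on compound 2 at > 72 ug/mL as a limit only. Compound 4 is estimated at 75 ug/mL with an expected range of 40 ug/mL to 90 ug/mL in this read-out.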

Compound 4, solubility: > 83 ug/mL
Compound 4 ended at the assay's limit (the forecaster's own chance of this, stated with the estimate: 70%); middle value at least 1.1-fold (0.04 log units) from the limit.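

The step from compound 2 to compound 4 cannot be read, as both values in this assay are limits. The compounds shown leave open how far the actual solubility of any of the four compounds lies beyond its limit.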